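This account rests on a few compounds, and the source may have more. Where it says the series, first, only, none or still open, it means among the compounds named here.

Compound 1, `COc1ccc2c(/C=C/C(=O)c3cc(N)c(OC)c(OC)c3)cn(C)c2c1`: 356 nM
Compound 2, `COc1cc(C(=O)/C(C)=C/c2c[nH]c3ccccc23)cc([Se]C)c1OC`: 34 nM
Compound 3, `COc1ccc2c(/C=C(\C)C(=O)c3cc(OC)c(OC)c([Se]C)c3)c[nH]c2c1`: 21 nM

In a functional assay on HeLa cells (Homo sapiens) for antiproliferative activity, read by MTT assay, with a stated time of 48 h (a higher number here means a weaker inhibitor, a lower number a stronger inhibitor), compound 2 gives 34 nM. Among the three measured compounds this is the second highest number; its nearest neighbour is compound 3, with a 1.6-fold lower number from compound 2 to compound 3 (0.21 log units; within the scatter), a step that brings methoxy in place of hydrogen on an aromatic carbon and stays within the scatter. The furthest is compound 1, whose number is higher by a margin beyond the scatter, but compound 1 differs from compound 2 in several places at once, so its value alone says nothing about any single change.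

The compound now in question is compound 4, `COc1cc(C(=O)/C(C)=C/c2cn(C)c3ccccc23)cc([Se]C)c1OC`. It differs from compound 2 only as follows: methyl in place of hydrogen on an aromatic nitrogen. For the measured compounds named here, no measured step isolates this change. Going by the values given here, the only single-place step available, from compound 2 to compound 3, concerns a different group and a different place and is itself within the scatter. Compound 1 carries the methyl on the aromatic nitrogen as well, but its other differences prevent any reading of that feature from its value.

Among the compounds with values here, with no step bearing directly on the change, the expectation for compound 4 is a number close to that of compound 2, with a 1.3-fold higher number from compound 2 to compound 4 (0.12 log units; within the scatter) not beyond the scatter. Compound 4 is therefore estimated at 45 nM, within a range of 18 nM to 110 nM.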

Compound 4, half-maximal inhibitory concentration: 63 nM
The estimate for compound 4 lay 1.4-fold (0.15 log units) below the measured number; the range from low to high includes it.
By their numbers in this assay, from the lowest: compounds 3, 2 and 4 (each within the scatter of the next, the first and the last beyond it); then compound 1.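

Methyl in place of hydrogen on an aromatic nitrogen now has a reading of its own in this assay, with a 1.9-fold higher number from compound 2 to compound 4 (0.27 log units; within the scatter), so compounds 2 and 4 stand within the scatter of each other and this pair shows that the hydrogen on this nitrogen can give way to a methyl with the number staying within that scatter. Compound 1 also carries this methyl, but it differs from compound 2 in several places at once, so only the present pair isolates the change, and the reading holds for this pair alone. Nothing among the data shown offers an explanation for how closely the two numbers lie.

The compounds shown leave open whether a longer chain such as propyl, or an amine or a carboxylic acid carried on a short chain, would be tolerated on this same aromatic nitrogen as the methyl is. They also leave open whether the methyl would give a similar reading on the core of compound 3, which carries an additional methoxy, since the step shown here rests on the core of compound 2 only.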